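The compounds below may be only part of what the source reports. "The series", "measured", "known", "first", "only" and "open" are said of these compounds alone.

Compound 1: `C/N=C(\S)NCCCCn1nc(C)ccc1=O`, in a functional assay on the whole organism (stomach) with Rattus norvegicus as the target (a lower number here means that less compound is needed, a higher number that more compound is needed for the effect), compound 1 gives > 100 mg/kg, a limit of the assay.
Compound 2: `C/N=C(/NC#N)NCCCCn1nc(N(C)C)ccc1=O`, in this assay compound 2 gives > 100 mg/kg, also a limit.

Compound 2 therefore stands at the limit, where both measured values sit (the limit of > 100 mg/kg in this assay, at which 2 of the 2 values shown sit). Compound 3, `C/N=C(/NC#N)NCCCCn1nc(Nc2ccccc2)ccc1=O`, differs from compound 2 by anilino in place of dimethylamino on an aromatic carbon. Going by the values given here, no measured step between compounds is available, so the size of the step from compound 2 to compound 3 is expected only as an at least 1.2-fold lower number from compound 2 to compound 3 (0.09 log units; that floor lies within the scatter), likely with no clear direction beyond the scatter. For compound 3 the expected dose for half-maximal effect is 80 mg/kg, within a range from 20 mg/kg to 300 mg/kg.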

Compound 3, dose for half-maximal effect: > 100 mg/kg
Compound 3 gave a limit, no number; the forecaster's own chance of this, stated with the estimate: 65%; middle value at least 1.2-fold (0.09 log units) from the limit.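

No step can be read between compound 2 and compound 3, as both stay at the limit: the limit of > 100 mg/kg in this assay, at which 3 of the 3 values shown sit.
The compounds shown leave open the dose at which any of them reaches half-maximal effect in this assay and whether anilino in place of dimethylamino changes it.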